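A few compounds are considered here, and "the series" means these few. Any claim that something is new, unique, unknown or untested is made for them only; others in the source may bear on it.

In an assay on brain for inhibition of Monoglyceride lipase (Mus musculus), with a stated time of 30 min (a lower number here means a stronger inhibitor, a higher number a weaker inhibitor), compound 1 `O=C(OC(C(F)(F)F)C(F)(F)F)N1CCN(Cc2ccc(C(F)(F)F)cc2N2CCCCC2)CC1` gives 130 nM, compound 2 `O=C(OC(C(F)(F)F)C(F)(F)F)N1CCN(Cc2ccc(C(F)(F)F)cc2N2[C@@H]3CC[C@H]2COC3)CC1` gives 48 nM and compound 3 `O=C(OC(C(F)(F)F)C(F)(F)F)N1CCN(Cc2ccc(C(F)(F)F)cc2N2CC[C@H](O)C2)CC1` gives 15 nM. Compound 3 has the lowest number of the three: the steps of an 8.7-fold lower number from compound 1 to compound 3 (0.94 log units; beyond the scatter) and a 3.2-fold lower number from compound 2 to compound 3 (0.51 log units; beyond the scatter) both lie beyond the scatter, as does a 2.7-fold lower number from compound 1 to compound 2 (0.43 log units; beyond the scatter). Compound 4 `O=C(OC(C(F)(F)F)C(F)(F)F)N1CCN(Cc2ccc(C(F)(F)F)cc2N2CC[C@@H](O)C2)CC1` differs from compound 3 in one respect only: the two compounds have the same atoms and bonds and differ only in configuration as drawn: 1 of 1 stereo elements differ; a stereocentre at a saturated ring carbon is drawn S in compound 3 and R in compound 4. Within the data shown here, none of the measured steps is of this kind; each of them exchanges one ring for another, so they offer no direct guide, and a small step in either direction, or none beyond the scatter, is expected. Compound 4 is expected to give 25 nM in this assay, within 8 nM to 80 nM. This corresponds to an expected step of a 1.7-fold higher number from compound 3 to compound 4 (0.22 log units; within the scatter).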

Compound 4, half-maximal inhibitory concentration: 8 nM
The estimate for compound 4 lay 3.1-fold (0.49 log units) above the measured number; the measured number falls inside the stated range.
By their numbers in this assay, from the lowest: compounds 4 and 3 (each within the scatter of the next); then compound 2; then compound 1.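

In this assay, the step between the two drawn configurations of the 3-hydroxypyrrolidin-1-yl group is a 1.9-fold lower number from compound 3 to compound 4 (0.27 log units; within the scatter), so this stereocentre shows no effect on the number beyond the scatter. Among these compounds, it is the only step here that changes no atoms: the fact that compounds 3 and 4 differ only in the configuration as drawn. The second configuration also stands clear of the other rings, with a 6.0-fold lower number from compound 2 to compound 4 (0.78 log units; beyond the scatter) and a 16-fold lower number from compound 1 to compound 4 (1.21 log units; beyond the scatter), so the advantage over piperidin-1-yl holds for both configurations.

Going by these compounds, what a methoxy group or an amine in place of the hydroxyl would give remains open, as does whether the hydroxyl is needed at all.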